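Series notes: amine replacement at the shared core

A few compounds are considered here, and "the series" means these few. Any claim that something is new, unique, unknown or untested is made for them only; others in the source may bear on it.

Measured so far:
compound 1 `Cc1cc(Nc2ccc(F)cc2)nc(SCc2nc3ccccc3[nH]2)n1`: 56200 nM
compound 2 `Cc1cc(Nc2ccc(Br)cc2)nc(SCc2nc3ccccc3[nH]2)n1`: 37100 nM

In a functional assay on PC-3 cells (Homo sapiens) for cytotoxicity, read by MTT assay, with a stated time of 72 h (on this read-out lower numbers stand for stronger inhibition and higher numbers for weaker inhibition), compound 1 gives 56200 nM and compound 2 gives 37100 nM. Going by the values given here, the only step measured between them is a 1.5-fold lower number from compound 1 to compound 2 (0.18 log units; within the scatter). Compound 2 thus holds the lowest of the two numbers, but its gap to compound 1 is within the scatter, so no ranking follows from it.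

Compound 3 `Cc1cc(N2CCCCC2)nc(SCc2nc3ccccc3[nH]2)n1` has not yet been measured in this assay. Its change from compound 2 is piperidin-1-yl in place of (4-bromophenyl)amino on an aromatic carbon. Among the compounds with values here, no measured step bears on this change: the single step known concerns a halogen exchange on a part of the molecule that is removed entirely here, so it gives no guide. Loss of the aromatic ring and of the hydrogen-bond donor is untested in the series.

The expectation is therefore a step of a 1.3-fold higher number from compound 2 to compound 3 (0.13 log units; within the scatter), with a wide range. Compound 3 is estimated at 50000 nM, between 15000 nM and 150000 nM.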

Compound 3, half-maximal inhibitory concentration: > 100000 nM
Compound 3 gave a limit, no number (the forecaster's own chance of this, stated with the estimate: 20%); middle value at least 2.0-fold (0.30 log units) from the limit.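

In this assay, compound 3 gives a limit and not a number: the limit of > 100000 nM in this assay, at which 1 of the 3 values shown sits.

The step of an at least 2.6-fold higher number from compound 2 to compound 3 (0.43 log units; beyond the scatter) shows that this position on the shared core can register a change beyond the scatter, which the halogen exchange between compound 1 and compound 2 did not show. The step of an at least 1.7-fold higher number from compound 1 to compound 3 (0.25 log units; that floor lies within the scatter) is weaker evidence, as its floor does not separate that pair.

The change removes the six-membered aromatic ring of carbon and the hydrogen-bond donor together, so the compounds shown leave open which of the two matters, or whether both do. Cyclohexylamino would keep the amine hydrogen without the aromatic ring, and (4-bromophenyl)(methyl)amino would keep the aromatic ring without that hydrogen.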